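The source may hold more compounds than are shown below. What is called first, only, known or untested is meant among the compounds shown, and "the series" means these compounds.

Compound 1 `CN1CCc2nc(C#Cc3cccc(F)c3)sc2C1` in an assay on HEK293 cells for negative allosteric modulation of metabotropic glutamate receptor 5 (Homo sapiens), read by FLIPR, with a stated time of 1 h (on this read-out higher numbers stand for weaker inhibition and lower numbers for stronger inhibition), gives > 10000 nM, and this is a limit of the assay rather than a number.
Compound 2 `Fc1cccc(C#Cc2nc3c(s2)CN(C2CCC2)CC3)c1` in this assay gives 200 nM.
Compound 3 `Fc1cccc(C#Cc2nc3c(s2)CN(C2CCOC2)CC3)c1` in this assay gives 400 nM.

Among the two numbers shown, compound 3 has the higher one; its nearest neighbour is compound 2, and the two lie within the usual scatter of each other. Compound 4 `O=C(C1CC(F)(F)C1)N1CCc2nc(C#Cc3cccc(F)c3)sc2C1` differs from compound 3 at a single place: (3,3-difluorocyclobutyl)carbonyl in place of oxolan-3-yl on an amine nitrogen in a ring. All three measured steps concern this same ring nitrogen. Replacing the methyl of compound 1 by a ring substituent gave an at least 50-fold lower number from compound 1 to compound 2 (1.69 log units; beyond the scatter) and an at least 25-fold lower number from compound 1 to compound 3 (1.39 log units; beyond the scatter), both large, while exchanging one ring substituent for another gave only a 2.0-fold higher number from compound 2 to compound 3 (0.30 log units; within the scatter). Every measured compound carries a basic amine at this position; none carries a carbonyl-bearing substituent there, so the measured steps give no direct scale for the change in compound 4, only the indication that a ring substituent on this nitrogen is compatible with strong inhibition. Among the compounds with values here, with no precedent for the carbonyl, the expectation is held loosely and set nearer the weaker side. Compound 4 is therefore expected to give 1500 nM, within 250 nM to 9000 nM. This corresponds to an expected step of a 3.8-fold higher number from compound 3 to compound 4 (0.57 log units; beyond the scatter).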

Compound 4, half-maximal inhibitory concentration: > 10000 nM
Compound 4 ended at the assay's limit; the forecaster's own chance of this, stated with the estimate: 20%; at least 6.6-fold (0.82 log units) between middle value and limit.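

The earlier compounds shown here showed that a ring substituent on this amine nitrogen could go with strong inhibition, but compound 4 shows that a ring there is not enough: putting (3,3-difluorocyclobutyl)carbonyl in place of oxolan-3-yl gives an at least 25-fold higher number from compound 3 to compound 4 (1.39 log units; beyond the scatter), and putting it in place of cyclobutyl gives an at least 50-fold higher number from compound 2 to compound 4 (1.69 log units; beyond the scatter). In this assay compound 4 gives > 10000 nM, which is a limit of the assay and not a number, so these two steps fix only a minimum size. The step between compound 1 and compound 4 cannot be read, and the scale ends for both compounds at the same point: the limit of > 10000 nM in this assay, at which 2 of the 4 values shown sit.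

The compounds shown do not separate the carbonyl from the two fluorines, since the change brings both at once; a plain cyclobutylcarbonyl group, or a 3,3-difluorocyclobutyl group bonded directly to the ring nitrogen, would tell the two apart. They also leave open how other groups on this nitrogen would behave, such as an acetyl group, an isopropyl group or a piperidin-4-yl ring.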